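The source may report more compounds than this note shows. Statements on the series, on what has been measured and on what is new or still open speak of the compounds shown alone.

Measured so far:
compound 1, `c1ncc2c(n1)CCCCCCCCCC2`: in a functional assay on the whole organism for inhibition, with Rattus norvegicus as the target, with stated times of 1 h and 3.5 h, at a dose of 100 mg/kg by the oral route (on this read-out lower numbers stand for less inhibition and higher numbers for more inhibition at the one dose given (going by the name of the read-out)), compound 1 gives < 5%, which is a limit of the assay and not a number.
compound 2, `Cc1ncc2c(n1)CCCCCCCCCC2`: in this assay compound 2 gives < 5%, again a limit.
compound 3, `Cc1nnc2c(n1)CC(C(C)(C)C)CC2`: in this assay compound 3 gives < 5%, also a limit.

All three values sit at the same limit, as the limit of < 5% in this assay, at which 3 of the 3 values shown sit, shows. The change hydrogen in place of methyl on an aromatic carbon therefore gives a step that the two limits leave unreadable from compound 2 to compound 1. How the core of compound 3 differs from the core of compound 2 is not broken down here.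

Compound 4, `CC(C)(C)C1CCc2nncnc2C1`, has not been measured. It differs from compound 3 by hydrogen in place of methyl on an aromatic carbon. This is the same kind of change as that from compound 2 to compound 1, not the same one: the place in compound 3 lies on a ring with three nitrogen, two atoms from the ring nitrogen, whereas the place in compound 2 lies on a ring with two nitrogen. Because the limit of < 5% in this assay, at which 3 of the 3 values shown sit, holds all three measured values at the limit, the step is expected to be a step that the limit leaves unreadable from compound 3 to compound 4. Compound 4 is estimated at 3% in this assay, most likely reported as a limit.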

Compound 4, a percentage reported as inhibition, in the whole organism at one dose (the size of the read-out at that dose, not a potency): 49%
Beside the measured number, compound 4's estimate is 46 percentage points below it; the measured number lies above the stated range.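

In this assay, hydrogen in place of methyl on an aromatic carbon gives a number at least 44 percentage points higher from compound 3 to compound 4 (beyond the scatter). On the core of compound 2 the same kind of change gives a step that cannot be read, as the values there are limits: the limit of < 5% in this assay, at which 3 of the 4 values shown sit.
The result therefore shows a large effect of this change on the core of compound 3, but it does not show whether that effect carries over to the core of compound 2 or to any other core.

The compounds shown leave open how an amine or an ethyl group at the same place, between two ring nitrogen atoms, would compare with the hydrogen of compound 4. They also leave open whether the tert-butyl group of compound 4 contributes to its value.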